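The compounds below may be only part of what the source reports. "The series", "measured", "known", "first", "only" and "open" are said of these compounds alone.

In a functional assay on PC-3 cells (Homo sapiens) for inhibition, read by sulforhodamine B assay, with a stated time of 48 h, tested at 50 uM (a higher number here means more inhibition of growth at the concentration tested, a lower number less inhibition of growth), compound 3 `COc1ccc([C@@H]2C/C(=N/OCc3cn(-c4ccccc4CO)nn3)c3cc(CC=C(C)C)c(OC)cc3O2)cc1` gives 100%, the highest of the three numbers. Compound 1 `COc1ccc([C@@H]2C/C(=N/OCc3cn(-c4ccc(O)cc4)nn3)c3cc(CC=C(C)C)c(OC)cc3O2)cc1` gives 64% and compound 2 `COc1ccc([C@@H]2C/C(=N/OCc3cn(-c4ccc(Cl)cc4C)nn3)c3cc(CC=C(C)C)c(OC)cc3O2)cc1` gives 49%. Compound 4 `COc1ccc([C@@H]2C/C(=N/OCc3cn(-c4cc(OC)c(OC)c(OC)c4)nn3)c3cc(CC=C(C)C)c(OC)cc3O2)cc1` has not yet been measured. It carries 3,4,5-trimethoxyphenyl in place of 2-(hydroxymethyl)phenyl on an aromatic nitrogen. Three measured steps change this same group. Two large ones lead to compound 3: a number 36 percentage points higher from compound 1 to compound 3 (beyond the scatter) and a number 51 percentage points higher from compound 2 to compound 3 (beyond the scatter). The third, a number 15 percentage points lower from compound 1 to compound 2 (beyond the scatter), is modest. Neither other group matched 2-(hydroxymethyl)phenyl, so a large downward step is expected in this assay, estimated as a number 40 percentage points lower from compound 3 to compound 4 (beyond the scatter). Compound 4 is expected to give 60%, within an estimated range of 35% to 85%.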

Compound 4, percent growth inhibition at one concentration: 36%
The estimate for compound 4 lay 24 percentage points above the measured number; low and high end bracket the measured number.
By their numbers in this assay, from the lowest: compound 4; then compound 2; then compound 1; then compound 3.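

In this assay, 3,4,5-trimethoxyphenyl in place of 2-(hydroxymethyl)phenyl on the aromatic nitrogen gives a number 64 percentage points lower from compound 3 to compound 4 (beyond the scatter), the largest step yet seen at this position. The new group also stands under both remaining groups, with a number 13 percentage points lower from compound 2 to compound 4 (beyond the scatter) and a number 28 percentage points lower from compound 1 to compound 4 (beyond the scatter), so none of the three other groups shown matches 2-(hydroxymethyl)phenyl. Nothing measured here accounts for these steps. The compounds shown leave open whether the hydroxyl of the hydroxymethyl group is what matters, and whether 2-(aminomethyl)phenyl or 2-carboxyphenyl at the same place would hold the number of compound 3 100% in this assay.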